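From 1-hydroxyethyl to trifluoromethyl on a shared core

The compounds below may be only part of what the source reports. "The series", "measured", "known", "first", "only" and "open" are said of these compounds alone.

Measured in a functional assay on L1210 cells (Mus musculus) for inhibition; on this read-out higher numbers stand for weaker inhibition and lower numbers for stronger inhibition:
- Compound 1 `C#CCN(Cc1ccc2nc(C)nc(O)c2c1)c1cccc(C)c1`: > 5000 nM (a limit)
- Compound 2 `C#CCN(Cc1ccc2nc(C)nc(O)c2c1)c1cccc(CO)c1`: 48000 nM
- Compound 3 `C#CCN(Cc1ccc2nc(C)nc(O)c2c1)c1cccc(C(C)O)c1`: > 49000 nM (a limit)

Compound 3 stands at a limit in this assay, > 49000 nM, and not at a number. Compound 4 `C#CCN(Cc1ccc2nc(C)nc(O)c2c1)c1cccc(C(F)(F)F)c1` carries trifluoromethyl in place of 1-hydroxyethyl on an aromatic carbon, meta to a large group: trifluoromethyl in place of 1-hydroxyethyl on an aromatic carbon.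

The nearest measured change is a step that the two limits leave unreadable from compound 1 to compound 3, which concerns the same position but gives no usable size. The same holds for a step that the limit leaves unreadable from compound 1 to compound 2. The remaining measured change, an at least 1.0-fold higher number from compound 2 to compound 3 (0.00 log units; that floor lies within the scatter), also sets no size for the coming step. Within the data shown here, compound 2, at 48000 nM, is the only true number, so it anchors the estimate at the weak end of this assay.

A moderate step toward stronger inhibition is expected, though with low confidence, and another limit would be no surprise. The estimated step is an at least 3.2-fold lower number from compound 3 to compound 4 (0.51 log units; beyond the scatter). For compound 4 the estimate is 15000 nM, with an expected range from 3000 nM to 60000 nM.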

Compound 4, half-maximal inhibitory concentration: > 2200 nM
Compound 4: a limit, no number (the forecaster's own chance of this, stated with the estimate: 45%); the middle value is on the limit's open side.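

In this assay compound 4 gives only a limit, > 2200 nM, so its steps from compound 1, compound 2 and compound 3 cannot be read. The compounds shown leave open how strongly compound 4 inhibits and how trifluoromethyl compares with methyl, hydroxymethyl or 1-hydroxyethyl on the shared core.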